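The compounds below may be only part of what the source reports. "The series", "measured", "known", "first", "only" and "open" are said of these compounds alone.

Measured so far in a functional assay on RT-112 cells (Homo sapiens) for antiproliferative activity, read by MTT assay, with a stated time of 72 h; on this read-out lower numbers stand for stronger inhibition of growth and higher numbers for weaker inhibition of growth:
- compound 1 `COc1cc(Nc2ncnc3c(NC(=O)Nc4ccc(C)cc4C)cccc23)cc(OC)c1` gives 1290 nM
- compound 2 `COc1cc(Nc2ncnc3c(NC(=O)Nc4ccc(Cl)c(Cl)c4)cccc23)cc(OC)c1` gives 6230 nM

Compound 2 holds the higher of the two numbers, which makes it the weaker growth inhibitor of this pair. Compound 3 `COc1cc(Nc2ncnc3c(NC(=O)Nc4ccc(F)cc4F)cccc23)cc(OC)c1` has not yet been measured. It carries 2,4-difluorophenyl in place of 3,4-dichlorophenyl on an amide-type nitrogen, and the change counts as 2,4-difluorophenyl in place of 3,4-dichlorophenyl on an amide-type nitrogen with the shared core left as it is.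

Among the measured compounds shown here, only one measured step bears on this change, since it falls at the same place. That step is a 4.8-fold higher number from compound 1 to compound 2 (0.68 log units; beyond the scatter) and it is modest in size. It brought in 3,4-dichlorophenyl in place of 2,4-dimethylphenyl. For the measured compounds named here, no measured compound yet carries fluorine, so the guide is thin. Compound 3 with 2,4-difluorophenyl resembles in name the 2,4-dimethylphenyl of compound 1 at 1290 nM and for that reason is expected to move back toward it, though perhaps not all the way. The expected change is a 2.5-fold lower number from compound 2 to compound 3 (0.40 log units; beyond the scatter) in this assay and it remains a modest one. For compound 3 the estimated value is 2500 nM with an expected range from 800 nM to 7000 nM in this measurement.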

Compound 3, concentration for 50% growth inhibition: 2460 nM
Compound 3: middle estimate off by 1.0-fold (0.01 log units), on the high side; measured number inside the range.
By their numbers in this assay, from the lowest: compounds 1 and 3 (each within the scatter of the next); then compound 2.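

In this assay, replacing 3,4-dichlorophenyl with 2,4-difluorophenyl on the amide-type nitrogen gives a 2.5-fold lower number from compound 2 to compound 3 (0.40 log units; beyond the scatter), so the number at this position also shifts between two halogen-bearing phenyl groups, and not only when 2,4-dimethylphenyl is exchanged for 3,4-dichlorophenyl. The comparison of the two 2,4-substituted groups gives a 1.9-fold higher number from compound 1 to compound 3 (0.28 log units; within the scatter), which lies within the usual scatter, so 2,4-difluorophenyl and 2,4-dimethylphenyl cannot be told apart here, while compound 2 stands apart from both. Nothing available explains why these numbers differ.

The step to compound 3 changes both the halogen and the positions it occupies on the ring, so these compounds cannot show whether the separation of compound 2 follows chlorine or the 3,4-substitution; 2,4-dichlorophenyl and 3,4-difluorophenyl would separate the two. On these data alone, it also remains open how an unsubstituted phenyl, or a phenyl carrying methoxy or trifluoromethyl, would read at this position, and whether the pattern would hold with any change elsewhere on the shared core.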